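From compound 3 to compound 4: a smaller side group

The source may hold more compounds than are shown below. What is called first, only, known or untested is meant among the compounds shown, and "the series" means these compounds.

Among the measured compounds shown here, in a functional assay with Oryctolagus cuniculus as the target (a lower number here means a stronger inhibitor, a higher number a weaker inhibitor), compound 1 `C/N=C(/NC)Nc1nc(-c2ccc(OC)cc2)c(-c2ccc(OC)cc2)s1` gives 970 nM, the only value that is not a limit. Compound 2 `COc1ccc(-c2nc(/N=C(\N)[N+]3(C)CCCCC3)sc2-c2ccc(OC)cc2)cc1` is reported only as a limit, > 1000 nM. Compound 3 `COc1ccc(-c2nc(/N=C(\N)n3ccnc3)sc2-c2ccc(OC)cc2)cc1` also stands only at a limit, > 100 nM, so its true place is open. Compound 4 `COc1ccc(-c2nc(CN(C)C)sc2-c2ccc(OC)cc2)cc1` differs from it by a group of 4 heavy atoms (3 carbon, 1 nitrogen; no ring) in place of a group of 8 heavy atoms (4 carbon, 4 nitrogen; one five-membered aromatic ring with 2 hetero atoms), on an aromatic carbon. The measured steps offer little: an at least 1.0-fold higher number from compound 1 to compound 2 (0.01 log units; that floor lies within the scatter), while a step that the limit leaves unreadable from compound 1 to compound 3 and a step that the two limits leave unreadable from compound 2 to compound 3. None involves (dimethylamino)methyl, so the expectation leans on compound 1 at 970 nM. The expected step in this assay is toward a higher number, a step that the limit leaves unreadable from compound 3 to compound 4. For compound 4 the estimate is 1500 nM, with an expected range of 300 nM to 8000 nM.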

Compound 4, half-maximal inhibitory concentration: 96 nM
The estimate for compound 4 lay 16-fold (1.19 log units) above the measured number; measured number below the stated range.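

In this assay, (dimethylamino)methyl on this aromatic carbon gives a 10-fold lower number from compound 1 to compound 4 (1.00 log units; beyond the scatter), so a group with no ring and 0 hydrogen-bond donors is compatible with a stronger result here. Against the larger ring-bearing group, it gives an at least 10-fold lower number from compound 2 to compound 4 (1.01 log units; beyond the scatter). The remaining comparison yields only an at least 1.0-fold lower number from compound 3 to compound 4 (0.01 log units; that floor lies within the scatter), its true size open because that compound is reported only as a limit: the limit of > 100 nM in this assay, at which 1 of the 4 values shown sits.

The compounds shown leave open how a plain methyl, a longer aminoethyl chain or a morpholine ring on this carbon would compare with (dimethylamino)methyl. They also leave open whether the step holds with groups other than the two 4-methoxyphenyl groups.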